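Lengthening the hydroxycarbamoyl chain: working notes

This account rests on a few compounds, and the source may have more. Where it says the series, first, only, none or still open, it means among the compounds named here.

In a functional assay on HEL cells (Homo sapiens) for inhibition, read by MTT assay, with a stated time of 48 h (on this read-out higher numbers stand for weaker inhibition and lower numbers for stronger inhibition), compound 1 `O=C(CCCOC(=O)c1ccc2c(c1)no[n+]2[O-])NO` gives 2090 nM and compound 2 `O=C(CCCCOC(=O)c1ccc2c(c1)no[n+]2[O-])NO` gives 1210 nM. Among the measured compounds shown here, these two values lie within the scatter of each other, so compound 2 holds no separate place on the numbers so far.

Compound 3 `O=C(CCCCCOC(=O)c1ccc2c(c1)no[n+]2[O-])NO` is not yet measured. Its difference from compound 2 is (hydroxycarbamoyl)methyl in place of hydroxycarbamoyl on a saturated chain carbon, four bonds along the chain from an oxygen next to a carbonyl group.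

For the measured compounds named here, one measured step bears on this, the same replacement three bonds along the chain: a 1.7-fold lower number from compound 1 to compound 2 (0.24 log units; within the scatter), within the scatter. On that single step, no change beyond the scatter is expected in this assay. The expected step, a 1.3-fold lower number from compound 2 to compound 3 (0.13 log units; within the scatter), is small and leans the same way. The estimate for compound 3 is 900 nM, with an expected range of 400 nM to 2000 nM.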

Compound 3, half-maximal inhibitory concentration: 11600 nM
Estimate against measurement, compound 3: 13-fold (1.11 log units) below, and the stated range ends below it.
By their numbers in this assay, from the lowest: compounds 2 and 1 (each within the scatter of the next); then compound 3.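

Compound 3 shows that this chain position is not indifferent to length in this assay. The same replacement that stayed within the scatter one bond nearer the oxygen now gives a clear loss of inhibition (a 9.6-fold higher number from compound 2 to compound 3 (0.98 log units; beyond the scatter)), and the comparison across both extensions agrees (a 5.6-fold higher number from compound 1 to compound 3 (0.74 log units; beyond the scatter)), so compound 1 and compound 2 form one level on the numbers and compound 3 stands apart on the weaker side. Nothing measured here accounts for this sharp turn at (hydroxycarbamoyl)methyl in place of hydroxycarbamoyl.

From the compounds shown here alone, whether a longer chain would continue this loss, hold level or recover remains open. Going by these compounds, it is also open whether the loss depends on the hydroxycarbamoyl end, since a carboxylic acid at the same chain end does not appear in this set.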